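Compound 2 to Compound 4 on the Receptor Assay

The source may hold more compounds than are shown below. What is called first, only, known or untested is meant among the compounds shown, and "the series" means these compounds.

Measured so far:
Compound 1, `Cc1nc(S(C)(=O)=O)ccc1Oc1ncnc(OC2CCN(C(=O)OC(C)(C)CF)CC2)c1F`: 19.9 nM
Compound 2, `Cc1nc(S(C)(=O)=O)ccc1Oc1ncnc(OC2CCN(C(=O)O[C@H](C)CF)CC2)c1F`: 196 nM
Compound 3, `Cc1nc(S(C)(=O)=O)ccc1Oc1ncnc(OC2CCN(C(=O)SC3CCC3)CC2)c1F`: 8.51 nM

In a functional assay on isolated protein for inhibition of Glucose-dependent insulinotropic receptor (Homo sapiens), read by HTRF and cAMP accumulation (on this read-out higher numbers stand for an effect only at larger amounts of compound and lower numbers for an effect already at smaller amounts), compound 2 stands highest of the three numbers: its nearest neighbour is compound 1, at a 9.8-fold higher number from compound 1 to compound 2 (0.99 log units; beyond the scatter) when read in the other direction, and furthest off is compound 3, at a 23-fold lower number from compound 2 to compound 3 (1.36 log units; beyond the scatter). Compound 4, `Cc1nc(S(C)(=O)=O)ccc1Oc1ncnc(OC2CCN(C(=O)C3(C)CC3)CC2)c1F`, has not been measured. It differs from compound 2 in one place (a group of 4 heavy atoms (4 carbon; one three-membered non-aromatic ring of carbon only) in place of a group of 5 heavy atoms (3 carbon, 1 oxygen, 1 fluorine; no ring), on a carbonyl carbon).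

Going by the values given here, two measured steps bear on this change. Both replace a fluorine-bearing, ring-free group on the carbonyl carbon with a carbon ring: a 2.3-fold lower number from compound 1 to compound 3 (0.37 log units; beyond the scatter) and a 23-fold lower number from compound 2 to compound 3 (1.36 log units; beyond the scatter), the second starting from compound 2 itself. Both point the same way, toward lower numbers, and the step from compound 2 is the large one. The group entering compound 4 is a different ring from that in compound 3, so the size is uncertain, but the direction is expected to hold.

Compound 4 is therefore expected to show a clearly lower number than compound 2, about a 13-fold lower number from compound 2 to compound 4 (1.12 log units; beyond the scatter), with an estimate of 15 nM and a range from 5 nM to 50 nM.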

Compound 4, half-maximal effective concentration: 761 nM
The estimate for compound 4 lay 51-fold (1.71 log units) below the measured number; the measured number lies above the stated range.
By their numbers in this assay, from the lowest: compound 3; then compound 1; then compound 2; then compound 4.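

In this assay, 1-methylcyclopropyl on the carbonyl carbon gives the highest number of the four compounds: a 3.9-fold higher number from compound 2 to compound 4 (0.59 log units; beyond the scatter), a 38-fold higher number from compound 1 to compound 4 (1.58 log units; beyond the scatter), and an 89-fold higher number from compound 3 to compound 4 (1.95 log units; beyond the scatter). The result shows that a carbon ring at this position does not by itself go with a lower number, for the cyclobutylsulfanyl group of compound 3 and the 1-methylcyclopropyl group of compound 4 both carry one, yet these two compounds stand at opposite ends of the series, and compound 4 is the only one of the four whose group on the carbonyl carbon consists of carbon alone. Nothing measured here accounts for this rise.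

The ring and the atom joining it to the carbonyl carbon change together between compound 3 and compound 4, so their separate contributions cannot be told apart. From the compounds shown here alone, a cyclobutyl group placed directly on the carbonyl carbon, or a 1-methylcyclopropyl group joined to it through oxygen or sulfur, would bear on this question, and how either would read in this assay remains open.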